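This account rests on a few compounds, and the source may have more. Where it says the series, first, only, none or still open, it means among the compounds named here.

In a functional assay on HCT-116 cells (Homo sapiens) for antiproliferative activity, with a stated time of 72 h (a lower number here means a stronger inhibitor, a higher number a weaker inhibitor), compound 1 `CC(=O)Oc1ccccc1/C=C/c1nc2ccccc2c(=O)[nH]1` reaches only a limit of the assay, > 25000 nM. Compound 2 `CC(=O)Oc1ccccc1/C=C/c1nc(Nc2ccccc2I)c2ccccc2n1` also gives only a limit, > 25000 nM. Compound 3 `CC(=O)Oc1cccc(/C=C/c2nc3ccccc3c(=O)[nH]2)c1` alone gives a number, 15300 nM. Compound 4 `CC(=O)Oc1ccc(/C=C/c2nc3ccccc3c(=O)[nH]2)c(OC(C)=O)c1` keeps the core of compound 1 and differs from it as follows: acetoxy in place of hydrogen on an aromatic carbon. This places acetoxy in place of hydrogen on an aromatic carbon, meta to an acetoxy group and para to a large group. With only the value of compound 3, 15300 nM, as a guide, a modest gain in this assay is expected. A result at the limit remains possible. The expected change is an at least 1.3-fold lower number from compound 1 to compound 4 (0.14 log units; that floor lies within the scatter). For compound 4, the estimated value is 18000 nM, with an expected range from 7000 nM to 35000 nM.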

Compound 4, half-maximal inhibitory concentration: > 25000 nM
Compound 4 gave a limit, no number (the forecaster's own chance of this, stated with the estimate: 45%); middle value at least 1.3-fold (0.14 log units) from the limit.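

Compound 1 and compound 4 both stop at a limit in this assay, so no step can be read between them: the limit of > 25000 nM in this assay, at which 3 of the 4 values shown sit.

As far as these compounds go, whether acetoxy in place of hydrogen on an aromatic carbon changes the activity of compound 1 at all, in either direction, stays open.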